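Hydroxy at a saturated ring carbon of compound 1

This account rests on a few compounds, and the source may have more. Where it says the series, first, only, none or still open, it means among the compounds named here.

Within the data shown here, compound 1 `CO[C@@H]1[C@@H](O)[C@@H](O)[C@H]2O[C@]1(C)n1c3ccccc3c3c4c(c5c6ccccc6n2c5c31)C(=O)NC4` gives 1010 nM in an assay on isolated protein for inhibition of protein kinase C theta type (Homo sapiens), read by HTRF (a higher number here means a weaker inhibitor, a lower number a stronger inhibitor), the second highest of the three numbers so far. Compound 2 `CO[C@@H]1[C@@H](O)[C@@H](O)[C@H]2O[C@]1(C)n1c3ccccc3c3c4c(c5c6ccccc6n2c5c31)C(=O)NC4=O` gives 1420 nM, which stands within the scatter of compound 1. Compound 3 `CO[C@@H]1[C@H](N(C)C=O)C[C@H]2O[C@]1(C)n1c3ccccc3c3c4c(c5c6ccccc6n2c5c31)C(=O)NC4` gives 250 nM, a gap from compound 1 that lies beyond the scatter. Compound 4 `CO[C@@H]1[C@@H](O)[C@@H](O)[C@H]2O[C@]1(C)n1c3ccccc3c3c4c(c5c6ccccc6n2c5c31)C(=O)N[C@@H]4O` is not yet measured in this assay; it differs from compound 1 by hydroxy in place of hydrogen on a saturated ring carbon, in words hydroxy in place of hydrogen on a saturated ring carbon. Among the measured compounds shown here, no measured pair shows this change, and compound 2 only shows that another alteration of the lactam region leaves the number within the scatter. A small step is therefore expected, a 1.4-fold lower number from compound 1 to compound 4 (0.16 log units; within the scatter), with no firm direction. Compound 4 is estimated at 700 nM, with a range of 250 nM to 2000 nM.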

Compound 4, half-maximal inhibitory concentration: > 2500 nM
Compound 4 gave a limit, no number (the forecaster's own chance of this, stated with the estimate: 3%); at least 3.5-fold (0.55 log units) between middle value and limit.
By their numbers in this assay, from the lowest: compound 3; then compounds 1 and 2 (each within the scatter of the next). At a limit, above all of these: compound 4.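

In this assay compound 4 gives > 2500 nM, a limit and not a number. Hydroxy in place of hydrogen on this saturated ring carbon, next to the ring nitrogen, gives an at least 2.4-fold higher number from compound 1 to compound 4 (0.39 log units; beyond the scatter), so this position is not indifferent to the change, and the size of the step is only a bound: the limit of > 2500 nM in this assay, at which 1 of the 4 values shown sits. Compound 2, with a carbonyl at this carbon, gives 1420 nM, within the scatter of compound 1.

Still open, on these data alone, is whether a methoxy, a methyl or an amine on this carbon would behave like hydroxy. Also open, as far as these compounds go, is whether the opposite configuration of the hydroxy would give the same result.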